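Growth inhibition series: methyl to trifluoromethoxy on the core

The source may hold more compounds than are shown below. What is called first, only, known or untested is meant among the compounds shown, and "the series" means these compounds.

Measured so far:
Compound 1 `CCOC(=O)/C=C1/C(=O)Nc2ccccc21` gives 81.4% in a functional assay on SAOS-2 cells (Homo sapiens) for inhibition, read by CCK-8 assay, with a stated time of 72 h, tested at 20 uM; a lower number here means less inhibition of growth, a higher number more inhibition of growth at the concentration tested.
Compound 2 `Cc1ccc2c(c1)/C(=C\C(=O)OC(C)(C)C)C(=O)N2` gives 83.7% in this assay.

Compound 2 holds the highest of the two numbers; compound 1 sits a little lower, within the scatter, so neither stands apart from the other. Compound 3 `CC(C)(C)OC(=O)/C=C1/C(=O)Nc2ccc(OC(F)(F)F)cc21` differs from compound 2 by trifluoromethoxy in place of methyl on an aromatic carbon. Among the compounds with values here, no measured pair covers a change of this kind, so the expectation rests on the two values alone. No step beyond the scatter is expected; the estimated step from compound 2 to compound 3 is a number 3.7 percentage points lower from compound 2 to compound 3 (within the scatter). Compound 3 is estimated at 80%, with a range from 65% to 92%.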

Compound 3, percent growth inhibition at one concentration: 80.1%
For compound 3 the middle estimate is 0.1 percentage points below the measured one, and the stated range covers the measured number.
By their numbers in this assay, from the lowest: compounds 3, 1 and 2 (each within the scatter of the next).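

In this assay trifluoromethoxy in place of methyl on this aromatic carbon gives a number 3.6 percentage points lower from compound 2 to compound 3 (within the scatter) and so does not separate the two compounds. This position therefore accepts a group of 5 heavy atoms, including a hydrogen-bond acceptor, in place of a single carbon without a step beyond the scatter in growth inhibition. Nothing measured here bears on the reason for this result.

Still open, going by these compounds, is whether an amine, a carboxylic acid or a longer chain such as butoxy on this aromatic carbon would also leave the number within the scatter. One pair cannot show whether the same holds with an ester other than the tert-butyl ester.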